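Sulfamate series: replacing the benzylamine with diisopentylamino

The compounds below may be only part of what the source reports. "The series", "measured", "known", "first", "only" and "open" are said of these compounds alone.

Of the compounds shown here, three on the shared sulfamate core have been measured. Compound 3 `CCN(Cc1ccc(F)cc1)c1cccc(C(=O)N2CCc3ccc(OS(N)(=O)=O)cc3C2)c1` gives 66.5% in an assay on HEK293 cells for inhibition of Steryl-sulfatase (Homo sapiens), tested at 1 uM; on this read-out lower numbers stand for a weaker effect and higher numbers for a stronger effect at the one concentration tested. Compound 1 `CCN(Cc1ccccc1)c1cccc(C(=O)N2CCc3ccc(OS(N)(=O)=O)cc3C2)c1` gives 69% in this assay, and compound 2 `CCN(Cc1ccc(Br)cc1)c1ccc(C(=O)N2CCc3ccc(OS(N)(=O)=O)cc3C2)cc1` gives 95.9% in this assay. Among the measured compounds shown here, on these numbers compound 3 stands lowest of the three; its nearest neighbour is compound 1, and the one step connecting them, a number 2.5 percentage points lower from compound 1 to compound 3 (within the scatter), lies within the scatter, so the two cannot be ordered. For the measured compounds named here, compound 2 differs from compound 3 in more than one place, so no single step leads to it; the gap between compound 2 and compound 3 is beyond the scatter.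

Compound 4 `CC(C)CCN(CCC(C)C)c1cccc(C(=O)N2CCc3ccc(OS(N)(=O)=O)cc3C2)c1` arises from compound 3 by diisopentylamino in place of ethyl(4-fluorobenzyl)amino on an aromatic carbon. Going by the values given here, the only measured step, a number 2.5 percentage points lower from compound 1 to compound 3 (within the scatter), concerns a fluoro on the aromatic ring that leaves here and says nothing about exchanging the whole ethyl(4-fluorobenzyl)amino group for a group with no ring. Among the compounds with values here, no measured step bears on this change, and the expectation rests on the level of compound 3 alone. Compound 4 is therefore estimated at 60%, with a wide range from 35% to 85%. The expected step is a number 6.5 percentage points lower from compound 3 to compound 4 (within the scatter), small and not expected to exceed the scatter.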

Compound 4, a percentage reported as inhibition, at one concentration (the size of the read-out at that concentration, not a potency): 75.9%
The estimate for compound 4 lay 15.9 percentage points below the measured number, and the stated range covers the measured number.
By their numbers in this assay, from the lowest: compounds 3, 1 and 4 (each within the scatter of the next); then compound 2.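

Across the group meta to a large group on the aromatic ring, the change from ethyl(4-fluorobenzyl)amino or benzyl(ethyl)amino to diisopentylamino gives, in this assay, a number 9.4 percentage points higher from compound 3 to compound 4 (within the scatter) and a number 6.9 percentage points higher from compound 1 to compound 4 (within the scatter), so compound 1, compound 3 and compound 4 cannot be ordered. Until now only a fluoro on the ring of this group had been exchanged; these steps show that the whole group, aromatic ring included, can give way to a group with no ring while the read-out stays within the scatter, so in these three compounds a ring in this group is not needed to reach this level. No measurement available here bears on why the read-out holds across this exchange.

Still open, as far as these compounds go, is whether this level survives much smaller groups at the same place, such as dimethylamino, a primary amine or a carboxylic acid. Compound 2 gives 95.9% and differs from these compounds in more than one place. The contribution of any single difference to this value remains unresolved.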